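Acylguanidine series: adding a second acyl group to compound 1

The compounds below may be only part of what the source reports. "The series", "measured", "known", "first", "only" and "open" are said of these compounds alone.

Compound 1 `CC(C)=CCC/C(C)=C/CC/C(C)=C/C(=O)NC(=N)N` is the reference point here. In a functional assay on U-373MG ATCC cells for inhibition, with U373 MG (Homo sapiens) as the target, read by MTT assay, with a stated time of 72 h (on this read-out lower numbers stand for stronger inhibition of growth and higher numbers for weaker inhibition of growth), compound 1 gives 21000 nM. Compound 2 `C=C1CCCC(C)(C)[C@@H]1CC/C(C)=C/C(=O)NC(=N)NC(=O)C=C(C)C` differs from compound 1 in more than one place; in this assay compound 2 gives 28800 nM. The two numbers lie within the usual scatter of each other, so on the figures so far compound 1 does not stand apart from compound 2. Compound 3 `CC(C)=CCC/C(C)=C/CC/C(C)=C/C(=O)NC(=N)NC(=O)C=C(C)C` differs from compound 1 in a single place: (2-methylprop-1-en-1-yl)carbonyl in place of hydrogen on an amine nitrogen. Going by the values given here, no step between measured compounds is known for this change, so it can only be judged indirectly. Because compound 2 gives 28800 nM while carrying the same (2-methylprop-1-en-1-yl)carbonyl on its guanidine, the step is expected to stay within the scatter, with no clear direction: a 1.2-fold higher number from compound 1 to compound 3 (0.08 log units; within the scatter). Compound 3 is accordingly estimated at 25000 nM, with a range of 10000 nM to 60000 nM.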

Compound 3, concentration for 50% growth inhibition: 15700 nM
For compound 3 the middle estimate is 1.6-fold (0.20 log units) above the measured one, within the range that was stated.
By their numbers in this assay, from the lowest: compounds 3, 1 and 2 (each within the scatter of the next).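

In this assay the change of hydrogen to (2-methylprop-1-en-1-yl)carbonyl on the amine nitrogen now has a direct reading, a 1.3-fold lower number from compound 1 to compound 3 (0.13 log units; within the scatter), where before it could only be judged indirectly. On this core the added acyl group therefore leaves the growth-inhibition read-out indistinguishable from that of the parent, and the second acyl group is accepted at this nitrogen without a measurable loss or gain. No supporting data are available that would explain this result.

As far as these compounds go, whether a different acyl group on the same nitrogen, such as acetyl or benzoyl, would move the number beyond the scatter remains open. A single pair also cannot show whether the same change behaves alike on other cores.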